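The source may hold more compounds than are shown below. What is called first, only, known or untested is meant among the compounds shown, and "the series" means these compounds.

Of the compounds shown here, three sharing one core have been tested in a functional assay on HOS-TE85 cells (Homo sapiens) for inhibition, read by CCK-8 assay, with a stated time of 72 h; on this read-out higher numbers stand for weaker inhibition and lower numbers for stronger inhibition. Compound 1 `Cc1cccc(N2C(=O)CSC2c2cccc(C(=O)NCCCCc3ccccc3)c2)c1` gives 93.2 nM. Compound 2 `COc1cc(F)ccc1N1C(=O)CSC1c1cccc(C(=O)NCCCCc2ccccc2)c1`, which carries 4-fluoro-2-methoxyphenyl in place of 3-methylphenyl on the amide-type nitrogen in the ring, gives 71.1 nM, a move of a 1.3-fold lower number from compound 1 to compound 2 (0.12 log units; within the scatter). Compound 3 `O=C(NCCCCc1ccccc1)c1cccc(C2SCC(=O)N2c2cccc(-c3c[nH]nn3)c2)c1` gives 110 nM; it differs from compound 1 by 1H-1,2,3-triazol-4-yl in place of methyl on an aromatic carbon, a move of a 1.2-fold higher number from compound 1 to compound 3 (0.07 log units; within the scatter), and from compound 2 by a 1.5-fold higher number from compound 2 to compound 3 (0.19 log units; within the scatter). Compound 3 thus sits within the scatter of both other compounds, and no ordering among the three can be drawn.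

Compound 4 `O=C(NCCCCc1ccccc1)c1cccc(C2SCC(=O)N2c2ccc(C3CC3)cc2)c1` is not yet measured. It differs from compound 3 by a group of 9 heavy atoms (9 carbon; one three-membered non-aromatic ring of carbon only, one six-membered aromatic ring of carbon only) in place of a group of 11 heavy atoms (8 carbon, 3 nitrogen; one five-membered aromatic ring with 3 hetero atoms, one six-membered aromatic ring of carbon only), on an amide-type nitrogen in a ring. The two steps that bear on this change are those that also exchange the group on the amide-type nitrogen in the ring, a 1.3-fold lower number from compound 1 to compound 2 (0.12 log units; within the scatter) and a 1.5-fold higher number from compound 2 to compound 3 (0.19 log units; within the scatter), and both lie within the scatter. Compound 4 is therefore expected to show no step beyond the scatter in this assay, estimated as a 1.2-fold lower number from compound 3 to compound 4 (0.09 log units; within the scatter). Compound 4 is expected to give about 90 nM, with a range from 45 nM to 180 nM.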

Compound 4, half-maximal inhibitory concentration in the HOS-TE85 assay: 217 nM
Compound 4: the middle estimate sits 2.4-fold (0.38 log units) below what was measured; measured number above the stated range.
By their numbers in the HOS-TE85 assay, from the lowest: compounds 2, 1, 3 and 4 (each within the scatter of the next, the first and the last beyond it).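

Among these compounds, in the HOS-TE85 assay, 4-cyclopropylphenyl is the first group on the amide-type nitrogen in the ring whose steps leave the scatter: a 3.1-fold higher number from compound 2 to compound 4 (0.48 log units; beyond the scatter) and a 2.3-fold higher number from compound 1 to compound 4 (0.37 log units; beyond the scatter). This position is therefore not wholly indifferent to the group it carries, although the steps are modest and the third comparison stays inside the scatter, with a 2.0-fold higher number from compound 3 to compound 4 (0.30 log units; within the scatter). The exchange that gives no step beyond the scatter on this read-out does give one in a physicochemical assay for solubility, read by turbidimetry, measured as kinetic solubility, at pH 7.4 (a lower number here means a less soluble compound, a higher number a more soluble compound), where compound 3 gives 20000 nM and compound 4 gives 2000 nM: the measured solubility of compound 3, 20000 nM, and of compound 4, 2000 nM, a 10-fold lower number (1.00 log units; beyond the scatter)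

The compounds shown leave open whether the higher number of compound 4 against compound 1 and compound 2 in the HOS-TE85 assay has anything to do with solubility, a question that a single pair of solubility values cannot settle. They also leave open whether a morpholine or a carboxylic acid in place of the cyclopropyl group on the phenyl ring would bring the number back to the level of compound 2 while holding the solubility of compound 3 in the physicochemical assay.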